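The source may report more compounds than this note shows. Statements on the series, on what has been measured and on what is new or still open speak of the compounds shown alone.

Working notes on the series. In a functional assay on CHO cells (Cricetulus griseus) for cytotoxicity (a higher number here means a weaker inhibitor, a lower number a stronger inhibitor), compound 1 `CN(Cc1cnc2ncncc2n1)c1ccc(C(=O)N[C@@H](CCC(=O)O)C(=O)O)cc1` gives 5 nM and compound 2 `CN(Cc1cnc2ncncc2n1)c1ccc(C(=O)N[C@@H](CCC(=O)OCOC(=O)C(C)(C)C)C(=O)OCOC(=O)C(C)(C)C)cc1` gives 8 nM. These two values lie within the scatter of each other, so compound 1 stands level with compound 2. Compound 3 `CN(Cc1cnc2ncncc2n1)c1ccc(C(=O)N[C@@H](CCC(=O)NC(CCC(=O)O)C(=O)O)C(=O)O)cc1` keeps the core of compound 1 and differs by (1,3-dicarboxypropyl)amino in place of hydroxy on a carbonyl carbon, with (1,3-dicarboxypropyl)amino in place of hydroxy on a carbonyl carbon. For the measured compounds named here, no measured step covers this change, so the expectation rests on the structural change alone. The expected move in this assay is toward a higher number, estimated as an 8.0-fold higher number from compound 1 to compound 3 (0.90 log units; beyond the scatter). The estimate for compound 3 is 40 nM, with an expected range of 8 nM to 300 nM.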

Compound 3, half-maximal inhibitory concentration: 20 nM
Compound 3: the middle estimate sits 2.0-fold (0.30 log units) above what was measured; measured number inside the range.
By their numbers in this assay, from the lowest: compounds 1 and 2 (each within the scatter of the next); then compound 3.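

In this assay, (1,3-dicarboxypropyl)amino in place of hydroxy on a carbonyl carbon gives a 4.0-fold higher number from compound 1 to compound 3 (0.60 log units; beyond the scatter). For the compounds shown here, this is the first step to show that a change at this position moves the number beyond the scatter, though the move is modest. No measurement on hand bears on the reason for this shift. Going by these compounds, what remains open is whether the shift follows the whole (1,3-dicarboxypropyl)amino group or only part of it. A plain amino group or a methylamino group on the same carbonyl carbon would separate these readings.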